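The source may hold more compounds than are shown below. What is called first, only, known or untested is meant among the compounds shown, and "the series" means these compounds.

Measured so far in a functional assay on B16-F10 cells (Mus musculus) for inhibition, read by colorimetric assay and MTT assay, with a stated time of 72 h; a lower number here means a stronger inhibitor, a higher number a weaker inhibitor:
- compound 1 `C=CCCCCOc1ncc(-c2ccccc2OC)n1C`: "not determined" (no result reported)
- compound 2 `C=CCCCCOc1ncc(-c2cc(Cl)ccc2OC)n1C`: 29000 nM

Among the compounds with values here, compound 2 gives 29000 nM, the only number so far. For compound 1 the entry reads "not determined" (no result reported), so the series offers no measured comparison and compound 2 cannot yet be ranked against anything.

Next is compound 3 `C=CCCCCOc1ncc(-c2cc(C(F)(F)F)ccc2OC)n1C`, which keeps the shared core of compound 2 and changes one substituent: trifluoromethyl in place of chloro on an aromatic carbon. Within the data shown here, no measured pair shows what this exchange does. The expectation in this assay is therefore a step no larger than the usual scatter, with no firm direction. The estimated change is a 1.2-fold lower number from compound 2 to compound 3 (0.06 log units; within the scatter). For compound 3 the expected value is 25000 nM, with an estimated range of 10000 nM to 60000 nM.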

Compound 3, half-maximal inhibitory concentration: 59000 nM
Compound 3: middle estimate off by 2.4-fold (0.37 log units), on the low side, and the stated range covers the measured number.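

In this assay, within the data shown here, the exchange of chloro for trifluoromethyl, on the aromatic carbon para to the methoxy group, gives a 2.0-fold higher number from compound 2 to compound 3 (0.31 log units; beyond the scatter) as the first readable step. The position is therefore not indifferent to this exchange, and the group with 4 heavy atoms gives the weaker inhibitor compared with the single chlorine, although the step is modest and rests on this one pair. Nothing available bears on the reason for this rise. 

With no number for compound 1, the step from the unsubstituted ring to chloro cannot be read. As far as these compounds go, whether the trend holds across other groups on this carbon, such as a nitrile, an amine or a carboxylic acid, remains open, as does the effect of a longer chain on the ether.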